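The source may hold more compounds than are shown below. What is called first, only, known or untested is meant among the compounds shown, and "the series" means these compounds.

Of the compounds shown here, three built on one shared core have been measured in an assay on CHO cells for binding affinity to Alpha-2B adrenergic receptor (Homo sapiens), read by radioligand binding; a lower number here means a stronger inhibitor, a higher number a weaker inhibitor. Compound 1 `CS(=O)(=O)c1ccc(Cl)cc1NCC1=NCCN1` gives only a limit in this assay, < 6310 nM. Compound 3 `CS(=O)(=O)c1cccc(F)c1NCC1=NCCN1` likewise gives only a limit in this assay, < 6310 nM. Compound 2 `CSc1cc(F)ccc1NCC1=NCCN1`, by contrast, gives a number in this assay, 851 nM. Compound 1 therefore stands at the limit of < 6310 nM in this assay, at which 2 of the 3 values shown sit, with no value of its own to anchor it. Compound 4 `CS(=O)(=O)c1ccc(C(F)(F)F)cc1NCC1=NCCN1` differs from compound 1 by trifluoromethyl in place of chloro on an aromatic carbon. Within the data shown here, no measured pair of compounds shows what this change does. The step from compound 1 to compound 4 is expected to be no larger than the scatter, roughly a step that the limit leaves unreadable from compound 1 to compound 4. Compound 4 is thus estimated at 4000 nM in this assay, within a range from 600 nM to 25000 nM.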

Compound 4, inhibition constant: < 6310 nM
Compound 4 ended at the assay's limit; the forecaster's own chance of this, stated with the estimate: 50%; the middle value lies beyond the limit too.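

Among these compounds, compound 1 and compound 4 both give only a limit in this assay, so no step between them can be read. On these data alone, what trifluoromethyl in place of chloro does to the binding affinity remains open.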